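The source may hold more compounds than are shown below. What is called first, only, known or untested is meant among the compounds shown, and "the series" means these compounds.

Working notes on the series. Among the compounds with values here, compound 2 `CC(C)(C)C(=O)OCO[P@@]1(=O)OCC(C)(C)[C@H](C(=O)NCCC(=O)OC2CCN(Cc3ccccc3)C2)O1` is the only member with a number in an ADME assay on blood (Homo sapiens) for pharmacokinetics; on this read-out higher numbers stand for a longer-lived compound and lower numbers for a shorter-lived compound: compound 2 gives 0.19 h. Compound 1 `CC(C)(C)C(=O)OCO[P@@]1(=O)OCC(C)(C)[C@H](C(=O)NCCC(=O)OCCc2ccccn2)O1` reaches in this assay only a limit, < 0.16 h (the limit of < 0.16 h in this assay, at which 1 of the 2 values shown sits). Within the data shown here, the one measured step, an at least 1.1-fold higher number from compound 1 to compound 2 (0.07 log units; that floor lies within the scatter), is therefore known only as a floor and tells nothing beyond the scatter. Compound 3 `CCOC(=O)CCNC(=O)[C@@H]1O[P@@](=O)(OCOC(=O)C(C)(C)C)OCC1(C)C` is not yet measured in this assay; it differs from compound 2 by ethyl in place of 1-benzylpyrrolidin-3-yl on an oxygen next to a carbonyl group, the shared core being kept. Among the measured compounds shown here, the single measured step sits at the same ester oxygen, and there the group that now leaves was the one that entered, with an at least 1.1-fold higher number from compound 1 to compound 2 (0.07 log units; that floor lies within the scatter) as the whole of the evidence. No step beyond the scatter is expected from compound 2 to compound 3, no change at the digits printed from compound 2 to compound 3 (within the scatter). Compound 3 is accordingly estimated at 0.19 h, between 0.08 h and 0.45 h.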

Compound 3, half-life: 0.28 h
Compound 3: the middle estimate sits 1.5-fold (0.17 log units) below what was measured; the measured number falls inside the stated range.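

In this assay, ethyl in place of 1-benzylpyrrolidin-3-yl on an oxygen next to a carbonyl group gives a 1.5-fold higher number from compound 2 to compound 3 (0.17 log units; within the scatter), so even removing both rings of that group produces no step beyond the scatter at this position. Hydrogen in place of pyridin-2-yl on the saturated chain carbon gives an at least 1.7-fold higher number from compound 1 to compound 3 (0.24 log units; that floor lies within the scatter), which is again only a floor. Compound 1 stands at a limit, so the true size of that step stays unknown: the limit of < 0.16 h in this assay, at which 1 of the 3 values shown sits.

Whether any group at this oxygen can move the read-out beyond the scatter remains open, since no step shown does so. Going by these compounds, how a longer straight chain than ethyl, or an amine without the benzyl group, would read in this assay also remains open.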